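Thiophene for furan on the saturated ring carbon

This account rests on a few compounds, and the source may have more. Where it says the series, first, only, none or still open, it means among the compounds named here.

Compound 3 `CC1=C(C(=O)OC2CCC2)C(c2ccco2)NC(=O)N1` stands lowest of the three numbers in an assay on membranes from HeLa cells for displacement of a labelled ligand from adenosine receptor A3 (Homo sapiens), read by scintillation counting, with a stated time of 180 min, tested at 1 uM (on this read-out lower numbers stand for less inhibition and higher numbers for more inhibition at the one concentration tested (going by the name of the read-out)), with 1%. For the measured compounds named here, compound 1 `CC1=C(C(=O)CC(C)C)C(c2ccsc2)NC(=O)N1` gives 14% in this assay, and compound 2 `CCN(CC)C(=O)C1=C(C)NC(=O)NC1c1ccsc1` gives 35%; the one measured step, a number 21 percentage points higher from compound 1 to compound 2 (beyond the scatter), concerns the group on the carbonyl carbon and not the aryl group on the saturated ring carbon.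

Compound 4 `CC1=C(C(=O)OC2CCC2)C(c2ccsc2)NC(=O)N1` differs from compound 3 by thiophen-3-yl in place of furan-2-yl on a saturated ring carbon. Going by the values given here, no measured step follows this exchange directly; compound 1 carries thiophen-3-yl but differs from compound 3 in two places, so the value of compound 1, 14%, cannot be set against compound 3 alone. With nothing in the series bearing on the aryl exchange, a step in this assay of no more than the scatter is expected, a number 7 percentage points higher from compound 3 to compound 4 (within the scatter), leaning if anywhere toward the small value of compound 1. Compound 4 is therefore estimated at 8%, within 0% to 25%.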

Compound 4, a percentage reported as inhibition, at one concentration (the size of the read-out at that concentration, not a potency): 3%
Compound 4: middle estimate off by 5 percentage points, on the high side; the range from low to high includes it.
By their numbers in this assay, from the lowest: compounds 3 and 4 (each within the scatter of the next); then compound 1; then compound 2.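

In this assay the exchange of furan-2-yl for thiophen-3-yl on the saturated ring carbon can now be read directly: a number 2 percentage points higher from compound 3 to compound 4 (within the scatter) does not separate the two groups while cyclobutyloxy sits on the carbonyl carbon. With thiophen-3-yl held fixed, the group on the carbonyl carbon gives the larger differences, a number 32 percentage points lower from compound 2 to compound 4 (beyond the scatter) and a number 11 percentage points lower from compound 1 to compound 4 (beyond the scatter) being both beyond the scatter, so among these compounds cyclobutyloxy goes with the lowest numbers. No evidence at hand accounts for these steps.

Going by these compounds, whether furan-2-yl and thiophen-3-yl would also remain within the scatter of each other with diethylamino or isobutyl on the carbonyl carbon stays open. Also open, on these data alone, is how a phenyl or pyridyl group on the saturated ring carbon, or a longer chain such as pentyloxy on the carbonyl carbon, would read here.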